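The source may hold more compounds than are shown below. What is called first, only, known or untested is meant among the compounds shown, and "the series" means these compounds.

Compound 1 `C#CCNC1CCc2c(SCc3cccc(C)c3)cccc21` is one of three analogues sharing the same core that were tested in an assay on isolated protein for inhibition of Amine oxidase [flavin-containing] B (Homo sapiens); on this read-out higher numbers stand for weaker inhibition and lower numbers for stronger inhibition. In this assay compound 1 gives > 100000 nM, which is a limit of the assay and not a number; it stands (the limit of > 100000 nM in this assay, at which 1 of the 3 values shown sits). Compound 2 `C#CCNC1CCc2c(SCCc3ccc(F)c(F)c3)cccc21` gives 3240 nM, and compound 3 `C#CCNC1CCc2c(SCc3ccc(OC)cc3)cccc21` gives 1900 nM. Compound 4 `C#CCNC1CCc2c(SCc3cccc(F)c3)cccc21` has not yet been measured; it differs from compound 1 by fluoro in place of methyl on an aromatic carbon. With compound 1 resting on a limit, the step from it cannot be measured, but compound 4 is expected to inhibit more strongly, a step of an at least 3.3-fold lower number from compound 1 to compound 4 (0.52 log units; beyond the scatter). Compound 4 is thus estimated at 30000 nM, within a range from 5000 nM to 150000 nM.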

Compound 4, half-maximal inhibitory concentration: 1480 nM
For compound 4 the middle estimate is 20-fold (1.31 log units) above the measured one, and the stated range ends above it.
By their numbers in this assay, from the lowest: compounds 4, 3 and 2 (each within the scatter of the next, the first and the last beyond it). At a limit, above all of these: compound 1.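

In this assay, the change from 3-methylphenyl to 3-fluorophenyl gives an at least 67-fold lower number from compound 1 to compound 4 (1.82 log units; beyond the scatter), so swapping one heavy atom at this place, meta to a large group, separates a measured compound from one at a limit. The earlier compounds shown here included no pair differing in one place, so they could not show this sensitivity. The value of compound 1 is a limit and not a number, so the full size of the step stays unknown: the limit of > 100000 nM in this assay, at which 1 of the 4 values shown sits.

As far as these compounds go, it remains open how chloro, methoxy or plain hydrogen would compare at this same place. From the compounds shown here alone, it is therefore also open whether methyl or fluoro is the exception here.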